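Capping the hydroxy of compound 1 as methoxymethoxy

This account rests on a few compounds, and the source may have more. Where it says the series, first, only, none or still open, it means among the compounds named here.

Working notes on a short chromone series. Compound 1 `CCCCCCCCCCCCCCCc1cc(=O)c2c(O)cc(O)c(C)c2o1` is the reference point. In a functional assay on MCF7 cells (Homo sapiens) for antiproliferative activity, read by MTT assay (a higher number here means a weaker inhibitor, a lower number a stronger inhibitor), compound 1 gives 17500 nM. Compound 3 `CC/C=C\C/C=C\C/C=C\CCCCCCCc1cc(=O)c2c(O)cc(O)c(C)c2o1` carries a longer unsaturated chain; in this assay compound 3 gives 17500 nM, so no change at the digits printed from compound 1 to compound 3 (within the scatter). Compound 2 `CCCCCCCCCCCCCCCc1cc(=O)c2c(O)c(C)c(O)c(C)c2o1` adds a methyl on an aromatic carbon. For compound 2 only a limit of the assay is recorded, > 67200 nM; this is the limit of > 67200 nM in this assay, at which 1 of the 3 values shown sits. Hence an at least 3.8-fold higher number from compound 1 to compound 2 (0.58 log units; beyond the scatter).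

The next compound is compound 4 `CCCCCCCCCCCCCCCc1cc(=O)c2c(O)cc(OCOC)c(C)c2o1`, which differs from compound 1 in one place: methoxymethyl in place of hydrogen on an oxygen on an aromatic ring. For the measured compounds named here, no measured step touches this oxygen, so neither the chain step nor the aromatic methyl step speaks directly to it. The only substitution near the core that has been measured, from compound 1 to compound 2, weakened the inhibitor, while the remote chain change left the number unchanged. On that thin basis a modest weakening is expected, a 2.0-fold higher number from compound 1 to compound 4 (0.30 log units; within the scatter). For compound 4 the estimate in this assay is therefore 35000 nM, with a range from 12000 nM to 100000 nM.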

Compound 4, half-maximal inhibitory concentration: > 67200 nM
Compound 4 was reported as a limit; the forecaster's own chance of this, stated with the estimate: 35%; middle value at least 1.9-fold (0.28 log units) away from the limit.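

In this assay, for the compounds shown here, capping the hydroxy as methoxymethoxy gives an at least 3.8-fold higher number from compound 1 to compound 4 (0.58 log units; beyond the scatter), the first measured evidence that this oxygen on the aromatic ring is sensitive to substitution. A change at this oxygen alone, with no added methyl on an aromatic carbon, is enough to move the number beyond the scatter, unlike the remote chain change, which gives no change at the digits printed from compound 1 to compound 3 (within the scatter). Compound 4 is recorded only as a limit, so the full size of this step stays unknown, and compound 2 shares that limit: the limit of > 67200 nM in this assay, at which 2 of the 4 values shown sit.

On these data alone, whether a small methyl ether on this oxygen would behave like methoxymethoxy remains open, as does the effect of an acetyl group there. The other hydroxy of the shared core is the same in all compounds shown, so its sensitivity to the same cap also remains open.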